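From a Cyclohexyl Ring to an Isopentyl Chain

The source may report more compounds than this note shows. Statements on the series, on what has been measured and on what is new or still open speak of the compounds shown alone.

Compound 1 `[O-][n+]1nc(NCOC2CCCCC2)[n+]([O-])c2ccccc21` gives the lowest of the two numbers in a functional assay on PC-3 cells (Homo sapiens) for cytotoxicity, read by MTT assay, with a stated time of 72 h (a higher number here means a weaker inhibitor, a lower number a stronger inhibitor), at 6670 nM. Compound 3 `CC(OCNc1n[n+]([O-])c2ccccc2[n+]1[O-])c1ccccc1` lies close to it, with 10700 nM, and this gap falls within the scatter, so the two stand together. Compound 2 `O=[N+]([O-])c1cccc(COCNc2n[n+]([O-])c3ccccc3[n+]2[O-])c1` reaches only a limit in this assay, at > 100000 nM, which is the limit of > 100000 nM in this assay, at which 1 of the 3 values shown sits. Compound 4 `CC(C)CCOCNc1n[n+]([O-])c2ccccc2[n+]1[O-]` has not yet been measured. It differs from compound 1 in one place: isopentyl in place of cyclohexyl on an oxygen on a saturated carbon. Among the measured compounds shown here, no measured step of this kind is available to draw on, so the step of a 1.2-fold higher number from compound 1 to compound 4 (0.08 log units; within the scatter) is expected to be small, not beyond the scatter, in either direction. Compound 4 is therefore estimated at 8000 nM, with a range from 3000 nM to 25000 nM.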

Compound 4, half-maximal inhibitory concentration: 7520 nM
Compound 4: the middle estimate sits 1.1-fold (0.03 log units) above what was measured; measured number inside the range.
By their numbers in this assay, from the lowest: compounds 1, 4 and 3 (each within the scatter of the next). At a limit, above all of these: compound 2.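

Putting isopentyl in place of cyclohexyl on an oxygen on a saturated carbon gives a 1.1-fold higher number from compound 1 to compound 4 (0.05 log units; within the scatter) in this assay. At this place, then, the six-membered ring is not needed to hold the number at the level of compound 1, and an open chain serves equally well. Nothing measured here gives a cause for this.

Going by these compounds, whether a much shorter chain such as ethyl would also hold this level remains open. So does the outcome of placing an amine or a carboxylic acid at the end of the chain.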